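The compounds below may be only part of what the source reports. "The series", "measured", "known", "first", "only" and "open" are said of these compounds alone.

Measured in an ADME assay on the whole organism (strain CD-1) for pharmacokinetics, with Mus musculus as the target, at a dose of 3 mg/kg by the intravenous route; a lower number here means less compound in the circulation, a higher number more compound in the circulation at the dose given
Compound 1 `CN(Cc1ccccc1OCCCCCC(=O)O)C(=O)c1ccc(-c2ccco2)cc1` gives 1100 ng.h/mL
Compound 2 `CN(Cc1ccccc1OCCC[C@@H]1C[C@@H]1C(=O)O)C(=O)c1ccc(-c2ccco2)cc1` gives 30100 ng.h/mL

Among the compounds with values here, of the two, compound 2 holds the higher number, and compound 1 is its only neighbour. Within the data shown here, the one measured step is a 27-fold higher number from compound 1 to compound 2 (1.44 log units; beyond the scatter) and it puts 2-carboxycyclopropyl in place of 2-carboxyethyl on the chain. Against compound 2, compound 3 `C/C(=C\CCCOc1ccccc1CN(C)C(=O)c1ccc(-c2ccco2)cc1)C(=O)O` carries 2-carboxyprop-1-en-1-yl in place of 2-carboxycyclopropyl on a saturated chain carbon, three bonds along the chain from an oxygen on an aromatic ring and so has 2-carboxyprop-1-en-1-yl in place of 2-carboxycyclopropyl on a saturated chain carbon, three bonds along the chain from an oxygen on an aromatic ring. The entering group has no ring, and compound 1, also without one at this place, gives 1100 ng.h/mL in this assay for comparison. A lower number is therefore expected, resting on this single step and falling short of its full size. The expected change is a 5.0-fold lower number from compound 2 to compound 3 (0.70 log units; beyond the scatter) on this reading. In this assay compound 3 is expected to give 6000 ng.h/mL within 1500 ng.h/mL to 20000 ng.h/mL on this estimate.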

Compound 3, area under the concentration-time curve: 1300 ng.h/mL
Estimate against measurement, compound 3: 4.6-fold (0.66 log units) above, and the stated range ends above it.
By their numbers in this assay, from the lowest: compounds 1 and 3 (each within the scatter of the next); then compound 2.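

In this assay there is a 23-fold lower number from compound 2 to compound 3 (1.36 log units; beyond the scatter), although the leaving and entering groups hold the same atoms joined differently, so composition alone does not set the number at this place. There is also a 1.2-fold higher number from compound 1 to compound 3 (0.07 log units; within the scatter), within the scatter, so 2-carboxyprop-1-en-1-yl and 2-carboxyethyl cannot be told apart here, and among these three compounds only the one carrying 2-carboxycyclopropyl stands apart from the others. No available evidence accounts for this difference.

From the compounds shown here alone, it remains open whether the high number depends on the defined stereocentres of the 2-carboxycyclopropyl group in compound 2, or would also hold with a 2-carboxycyclobutyl group at this place. Going by these compounds, it is also open whether the number would hold with a tetrazole in place of the carboxylic acid on the cyclopropane ring.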